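A Methyl Step Carried from One Core to Another

The compounds below may be only part of what the source reports. "The series", "measured", "known", "first", "only" and "open" are said of these compounds alone.

The measured compounds are:
compound 1, `COc1ccccc1-c1cc(O)c2cccnc2n1`, giving 27500 nM in a functional assay on HCT-116 cells (Homo sapiens); a higher number here means a weaker inhibitor of growth, a lower number a stronger inhibitor of growth;
compound 2, `COc1cccc(-c2cc(O)c3c(C)ccnc3n2)c1`, giving 44.7 nM in this assay;
compound 3, `COc1cccc(-c2cc(O)c3cccnc3n2)c1`, giving 36.3 nM in this assay.

Compound 1 stands apart from the other two: the gap from compound 2 to compound 1 and from compound 3 to compound 1 is well beyond the scatter of the assay, and compound 1 is the weakest inhibitor of growth among the three. Compound 1 and compound 3 are built from the same atoms joined differently; the difference between the two cores is not broken down here.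

Within the core of compound 3, one change is measured: methyl in place of hydrogen on an aromatic carbon, which gave a 1.2-fold higher number from compound 3 to compound 2 (0.09 log units; within the scatter). The unmeasured compound 4, `COc1ccccc1-c1cc(O)c2cc(C)cnc2n1`, carries the same kind of change on the core of compound 1: methyl in place of hydrogen on an aromatic carbon. It is not the same change, since the place differs: in compound 4 the methyl sits two atoms from the ring nitrogen, meta to a fused ring and para to a fused ring, whereas in compound 2 it sits ortho to a fused ring, meta to a fused ring and opposite the ring nitrogen.

Because the measured step of a 1.2-fold higher number from compound 3 to compound 2 (0.09 log units; within the scatter) lay within the scatter, compound 4 is expected to stay close to compound 1, a step of about a 1.1-fold lower number from compound 1 to compound 4 (0.04 log units; within the scatter). Compound 4 is therefore estimated at 25000 nM, with a range from 8000 nM to 80000 nM.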

Compound 4, concentration for 50% growth inhibition: 42700 nM
Beside the measured number, compound 4's estimate is 1.7-fold (0.23 log units) below it; the measured number falls inside the stated range.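

In this assay, the methyl in place of hydrogen gave a 1.6-fold higher number from compound 1 to compound 4 (0.19 log units; within the scatter), and set beside the earlier step, it does not differ from it: the same change on two cores in this assay, a 1.2-fold higher number (0.09 log units; within the scatter) from compound 3 to compound 2 and a 1.6-fold higher number (0.19 log units; within the scatter) from compound 1 to compound 4, 1.3-fold (0.10 log units) apart, within the scatter of two such steps. The change therefore left the number within the scatter on both cores, both on the core of compound 3, where compound 3 and compound 2 are of like strength, and on the core of compound 1, where the numbers stay far higher. Among these compounds, this shows only that a step within the scatter carried over between these two pairs; it does not show that the place of the methyl is without consequence, since place and core differ together here, and two pairs make no general rule.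

From the compounds shown here alone, whether each methyl place would give the same result on the other core remains open. So does whether a larger or different group at these places, such as an ethyl chain, an amine or a carboxylic acid, would also leave the number within the scatter.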